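The compounds below may be only part of what the source reports. "The series", "measured", "known", "first", "only" and "open" are said of these compounds alone.

Compound 2 `CCCC(=O)OCSc1ccccc1C(=O)NCCCCC(N)=O` is judged in an ADME assay on CEM-SS cells (Homo sapiens) for cytotoxicity, read by XTT assay, with a stated time of 6 days (on this read-out higher numbers stand for lower toxicity in this test and lower numbers for higher toxicity in this test), where compound 2 gives 51.7 uM. Compound 3 `CCCC(=O)OCSc1ccccc1C(=O)Nc1ccc(C(N)=O)cc1` gives 39 uM in this assay, a number that sits within the usual scatter of the value for compound 2, so the two cannot be told apart. Compound 1 `NC(=O)CCNC(=O)c1cccc(S)c1` is reported only as a limit of the measurement in this assay, where compound 1 gives > 100 uM; this is the limit of > 100 uM in this assay, at which 1 of the 3 values shown sits. Compound 4 `CCCC(=O)OCSc1ccccc1C(=O)NCC(=O)OC` has not yet been measured in this assay. It differs from compound 2 in one place: methoxycarbonyl in place of 3-carbamoylpropyl on a saturated chain carbon bound to an amide-type nitrogen. Within the data shown here, no measured pair shows a change of this kind, so the step is expected to be small, of no clear direction and not beyond the scatter, with a 1.1-fold lower number from compound 2 to compound 4 (0.06 log units; within the scatter) as its expected size. Compound 4 is thus estimated at 45 uM in this assay, between 18 uM and 100 uM.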

Compound 4, half-maximal toxic concentration: 27.3 uM
For compound 4 the middle estimate is 1.6-fold (0.22 log units) above the measured one; measured number inside the range.
By their numbers in this assay, from the lowest: compounds 4, 3 and 2 (each within the scatter of the next). At a limit, above all of these: compound 1.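

In this assay, the first step read at this position, on a saturated chain carbon bound to an amide-type nitrogen, is a 1.9-fold lower number from compound 2 to compound 4 (0.28 log units; within the scatter), so methoxycarbonyl can take the place of 3-carbamoylpropyl here without moving the read-out beyond the scatter. Nothing measured here accounts for the size of this step. Going by these compounds, whether an amine, a carboxylic acid or a longer chain at this place would move the number beyond the scatter stays open. On these data alone, whether the same change behaves alike on another core also stays open.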